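A few compounds are considered here, and "the series" means these few. Any claim that something is new, unique, unknown or untested is made for them only; others in the source may bear on it.

For the measured compounds named here, compound 1, `CCCCc1nc(N)c2nc(O)n(Cc3ccccc3)c2n1`, holds the lowest of the two numbers measured so far. In a functional assay on the whole organism for activation, with Mus musculus as the target (a lower number here means that less compound is needed, a higher number that more compound is needed for the effect), compound 1 gives 0.3 mg/kg. Going by the values given here, the only other measured compound, compound 2, `Nc1ncnc2c1nc(O)n2Cc1ccc(Cl)cc1`, gives 30 mg/kg in this assay, a far higher number that lies well beyond the usual scatter of repeated measurements, so the two compounds are clearly set apart.

Compound 3, `CCCCSc1nc(N)c2nc(O)n(Cc3ccccc3)c2n1`, has not yet been measured. It differs from compound 1 in a single place: butylsulfanyl in place of butyl on an aromatic carbon.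

Among the compounds with values here, no pair of measured compounds that differ in one place is available, so there is no measured step to lean on for this change. The chain keeps its length and the ring system is untouched, so only a modest shift, if any, is anticipated.

Compound 3 is therefore expected to give about 0.3 mg/kg in this assay, with a range from 0.1 mg/kg to 1 mg/kg. The step of no change at the digits printed from compound 1 to compound 3 (within the scatter) is estimated to be none beyond the scatter.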

Compound 3, minimum effective dose: 0.3 mg/kg
Compound 3: the middle estimate sits on the measured number at the digits printed; the measured number falls inside the stated range.
By their numbers in this assay, from the lowest: compounds 1 and 3 (each within the scatter of the next); then compound 2.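

In this assay, putting butylsulfanyl in place of butyl on this aromatic carbon, between two ring nitrogen atoms, gives no change at the digits printed from compound 1 to compound 3 (within the scatter). For the compounds shown here, this is the first change at this position with a measured outcome, and it shows that a sulfur atom can be added to the link between the core and the butyl chain without moving the dose beyond the scatter. No measurement is available that would explain this result.

Going by these compounds, it remains open whether other links would be accepted in the same way, such as the oxygen of a butoxy group or the nitrogen of a butylamino group. Also unresolved is how a shorter methylsulfanyl group or a longer hexylsulfanyl group would behave here.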